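The source may report more compounds than this note shows. Statements on the series, on what has been measured and on what is new or still open speak of the compounds shown alone.

Measured so far:
compound 1 `N=C(N)N/N=C/c1cccc(C(=N)N)c1` — 9100 nM
compound 2 `N=C(NO)N/N=C/c1cccc(C(=N)N)c1` — 14100 nM
compound 3 `N=C(N)N/N=C/c1cccc(C(=N)N)n1` — 10100 nM

All three numbers come from a functional assay on T-24 cells (Homo sapiens) for antiproliferative activity; a higher number here means a weaker inhibitor, a lower number a stronger inhibitor. Within the data shown here, the one change covered twice in the set is hydroxy in place of hydrogen on an amine nitrogen; between compound 1 and compound 2 it gave a 1.5-fold higher number from compound 1 to compound 2 (0.19 log units; within the scatter). Compound 3 sits on a different core from compound 1, and the difference between the two cores is not broken down here; the two values themselves lie within the scatter of each other. Compound 4 `N=C(NO)N/N=C/c1cccc(C(=N)N)n1` carries the same change on the core of compound 3: hydroxy in place of hydrogen on an amine nitrogen.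

For compound 4 the expected step is a 1.5-fold higher number from compound 3 to compound 4 (0.17 log units; within the scatter), because the identical change gave a 1.5-fold higher number from compound 1 to compound 2 (0.19 log units; within the scatter) and nothing else among the measured compounds bears on it. Compound 4 is accordingly estimated at 15000 nM, with the likely range from 8000 nM to 28000 nM.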

Compound 4, half-maximal inhibitory concentration: 32900 nM
The estimate for compound 4 lay 2.2-fold (0.34 log units) below the measured number; measured number above the stated range.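

On the core of compound 3, hydroxy in place of hydrogen on an amine nitrogen gives a 3.3-fold higher number from compound 3 to compound 4 (0.51 log units; beyond the scatter) in this assay. Set beside the same change on the core of compound 1, the size of the step does not separate the two cores: the same change on two cores in this assay, a 1.5-fold higher number (0.19 log units; within the scatter) from compound 1 to compound 2 and a 3.3-fold higher number (0.51 log units; beyond the scatter) from compound 3 to compound 4, 2.1-fold (0.32 log units) apart, within the scatter of two such steps. Among these compounds, the change can therefore be carried between these two cores without evidence of a core-dependent size, although only the step on the core of compound 3 lies beyond the scatter, and one pair of cores does not show that the change transfers generally.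

Open, from the compounds shown here alone, is how a methoxy or a methyl on the same amine nitrogen would read in this assay. Also open, going by these compounds, is whether hydroxy in place of hydrogen behaves alike on any further core.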